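Iodo for methyl on the urea aryl ring

The source may report more compounds than this note shows. Statements on the series, on what has been measured and on what is new or still open speak of the compounds shown alone.

Compound 1 `Cc1cccc(NC(=O)N[C@H](C)c2ccccc2)c1` and compound 2 `Cc1cccc(NC(=O)N[C@@H](C)c2ccccc2)c1` share one set of atoms and bonds and differ only in configuration as drawn. Among the compounds with values here, in an ADME assay on the whole organism with Oryza sativa as the target, tested at 1 uM (a lower number here means a stronger effect, a higher number a weaker effect of the compound at the concentration tested), compound 1 gives 98% and compound 2 gives 100%; the step of a number 2 percentage points higher from compound 1 to compound 2 (within the scatter) is the only measured step in the set, and it rests on the fact that compounds 1 and 2 differ only in the configuration as drawn alone. Compound 3 `Cc1ccc(NC(=O)N[C@@H](C)c2ccccc2)cc1` gives 99% in this assay, and the three numbers sit within the scatter of one another, so compound 2 is not set apart from either of its neighbours.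

Compound 4 `C[C@H](NC(=O)Nc1cccc(I)c1)c1ccccc1` has not been measured. It differs from compound 2 by iodo in place of methyl on an aromatic carbon. Within the data shown here, no measured step touches a change of this kind: the one known step, a number 2 percentage points higher from compound 1 to compound 2 (within the scatter), inverts a stereocentre and leaves every substituent in place, so it carries nothing over to the exchange of one aromatic substituent for another. With all three measured numbers close to the top of the read-out and no step beyond the scatter anywhere, no movement beyond the scatter is expected for a number 3 percentage points lower from compound 2 to compound 4 (within the scatter). Compound 4 is therefore estimated at 97% in this assay, with a range from 85% to 100%.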

Compound 4, a percentage reported as activity, at one concentration (the size of the read-out at that concentration, not a potency): 95%
The estimate for compound 4 lay 2 percentage points above the measured number; the measured number falls inside the stated range.
By their numbers in this assay, from the lowest: compounds 4, 1, 3 and 2 (each within the scatter of the next).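

Iodo in place of methyl on an aromatic carbon, meta to a large group, gives a number 5 percentage points lower from compound 2 to compound 4 (within the scatter) in this assay. Within the data shown here, this is the only measured step in the set that exchanges a substituent rather than a configuration, and it shows that at this place on the ring, methyl and iodo give numbers within the scatter of each other. Nothing on hand bears on why this exchange gives this result, or on any property of either group at this position.

Still open, going by these compounds, is whether an amine, a carboxylic acid or a longer chain at this place would give a number beyond the scatter of compound 2. Also open, on these data alone, is whether iodo gives a similar number at the ring position that carries methyl in compound 3.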